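Cyclopentyl in Place of Butyl: Expected Antiproliferative Effect

The source may report more compounds than this note shows. Statements on the series, on what has been measured and on what is new or still open speak of the compounds shown alone.

In a functional assay on NCI-H460 cells (Homo sapiens) for antiproliferative activity, read by CCK-8 assay, with a stated time of 72 h, tested at 8 uM (a lower number here means a weaker effect, a higher number a stronger effect of the compound at the concentration tested), compound 3 `CCCCn1cnc2c(Nc3cccc(Cl)c3)nc(NCOCc3ccc(/C=C/C(=O)Nc4ccccc4N)cc3)nc21` gives 51.1%, the second highest of the three numbers measured. Compound 2 `COC(CCn1cnc2c(NCc3ccc(C(=O)Nc4ccccc4N)cc3)nc(Cl)nc21)OC` gives 51.2%, which lies within the scatter of compound 3, while compound 1 `CCCCn1cnc2c(Nc3ccccc3)nc(NCOCc3ccc(/C=C/C(=O)Nc4ccccc4N)cc3)nc21` gives 34.2%. Among the measured compounds shown here, the only measured step is a number 16.9 percentage points higher from compound 1 to compound 3 (beyond the scatter), and it concerns chloro in place of hydrogen on an aromatic carbon, not the change now considered. For the measured compounds named here, compound 4 `Nc1ccccc1NC(=O)/C=C/c1ccc(COCNc2nc(Nc3cccc(Cl)c3)c3ncn(C4CCCC4)c3n2)cc1` differs from compound 3 by cyclopentyl in place of butyl on an aromatic nitrogen, a change that no measured pair covers. Going by the values given here, with no step bearing on cyclopentyl in place of butyl, one expects no step beyond the scatter, a number 0.1 percentage points lower from compound 3 to compound 4 (within the scatter). Compound 4 is therefore estimated at 51%, with a range from 36% to 66%.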

Compound 4, a percentage reported as inhibition, at one concentration (the size of the read-out at that concentration, not a potency): 46.1%
Compound 4: middle estimate off by 4.9 percentage points, on the high side; low and high end bracket the measured number.
By their numbers in this assay, from the lowest: compound 1; then compounds 4, 3 and 2 (each within the scatter of the next).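

Cyclopentyl in place of butyl on an aromatic nitrogen gives a number 5 percentage points lower from compound 3 to compound 4 (within the scatter) in this assay. This shows that, in the setting of compound 3, a five-membered non-aromatic ring can stand at this position in place of an open chain without a step beyond the scatter. Nothing measured here accounts for this result.

The compounds shown leave open how a methyl group, a longer chain such as hexyl, or a chain ending in an amine would read at this nitrogen. They also leave open whether the same change would read alike without the chloro group of compound 3.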